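Compound 4 as an Acetamido Variant of Compound 3

The source may report more compounds than this note shows. Statements on the series, on what has been measured and on what is new or still open speak of the compounds shown alone.

Three compounds have been measured in an assay on CHO cells for displacement of a labelled ligand from 5-hydroxytryptamine receptor 1D (Homo sapiens); on this read-out lower numbers stand for stronger inhibition and higher numbers for weaker inhibition:
Compound 1 `O=S(=O)(NCC1CCN(CCCc2c[nH]c3ccc(-n4cnnc4)cc23)CC1)c1ccccc1` gives 6.2 nM
Compound 2 `C[C@@H](NCC1CCN(CCCc2c[nH]c3ccc(-n4cnnc4)cc23)CC1)c1ccccc1` gives 1.4 nM
Compound 3 `c1ccc(CNCC2CCN(CCCc3c[nH]c4ccc(-n5cnnc5)cc34)CC2)cc1` gives 1.6 nM

Compound 3 stands second highest of the three numbers. Compound 2 is its nearest neighbour, and a 1.1-fold higher number from compound 2 to compound 3 (0.06 log units; within the scatter) lies within the scatter. Compound 1 is furthest away: a 3.9-fold lower number from compound 1 to compound 3 (0.59 log units; beyond the scatter) lies beyond the scatter.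

Compound 4 `CC(=O)Nc1ccc([C@H](C)NCC2CCN(CCCc3c[nH]c4ccc(-n5cnnc5)cc34)CC2)cc1` differs from compound 3 in one place: 1-(4-acetamidophenyl)ethyl in place of benzyl on an amine nitrogen. The methyl part of this change is covered by a 1.1-fold higher number from compound 2 to compound 3 (0.06 log units; within the scatter), which was within the scatter. Among the compounds with values here, the acetamido group has no precedent among the measured compounds. Compound 4 is therefore expected to show a 1.3-fold higher number from compound 3 to compound 4 (0.10 log units; within the scatter), no step beyond the scatter. Compound 4 is estimated at 2 nM, ranging from 0.6 nM to 7 nM.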

Compound 4, half-maximal inhibitory concentration: 0.6 nM
The estimate for compound 4 lay 3.3-fold (0.52 log units) above the measured number, within the range that was stated.
By their numbers in this assay, from the lowest: compound 4; then compounds 2 and 3 (each within the scatter of the next); then compound 1.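

In this assay, 1-(4-acetamidophenyl)ethyl on the amine nitrogen gives the first gain beyond the scatter among the carbon-linked groups at this position, with a 2.7-fold lower number from compound 3 to compound 4 (0.43 log units; beyond the scatter) and a 2.3-fold lower number from compound 2 to compound 4 (0.37 log units; beyond the scatter), whereas the methyl alone had stayed within it. Against phenylsulfonyl the gap widens to a 10-fold lower number from compound 1 to compound 4 (1.01 log units; beyond the scatter), the only large step so far. Nothing available explains this gain.

The compounds shown leave open whether the gain belongs to the acetamido group as such or would also come with an amine or a carboxylic acid in its place. They also leave open whether the opposite configuration at the defined stereocentre would give a similar number.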